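Fluoro for Hydrogen on an Aromatic Ring of Compound 1

The source may report more compounds than this note shows. Statements on the series, on what has been measured and on what is new or still open speak of the compounds shown alone.

Compound 1 `COc1cc(N(C)CCN(C)C)c(NC(=O)/C=C\C(C)C)cc1Nc1nccc(-c2cn(C)c3ccccc23)n1` gives 1820 nM in a functional assay on NCI-H1975 cells (Homo sapiens) for antiproliferative activity, read by MTT assay, with a stated time of 72 h (a higher number here means a weaker inhibitor, a lower number a stronger inhibitor), the lower of the two numbers shown. Compound 2 `CC/C=C\C(=O)Nc1cc(Nc2nccc(-c3cn(C)c4ccccc34)n2)c(OC)cc1N(C)CCN(C)C` gives 3860 nM, and the step of a 2.1-fold higher number from compound 1 to compound 2 (0.33 log units; beyond the scatter) is modest. Compound 3 `COc1cc(N(C)CCN(C)C)c(NC(=O)/C=C\C(C)C)cc1Nc1nccc(-c2cn(C)c3ccc(F)cc23)n1` differs from compound 1 by fluoro in place of hydrogen on an aromatic carbon, that is, 1-methyl-1H-indol-3-yl becoming 5-fluoro-1-methyl-1H-indol-3-yl. Within the data shown here, no measured step touches that ring; the only step seen sits on the unsaturated amide chain and says nothing about this change. Relative to compound 1, the expected change for compound 3 is a 1.0-fold lower number from compound 1 to compound 3 (0.00 log units; within the scatter), within the scatter. The estimate for compound 3 in this assay is 1800 nM, ranging from 800 nM to 4000 nM.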

Compound 3, half-maximal inhibitory concentration: 7360 nM
Estimate against measurement, compound 3: 4.1-fold (0.61 log units) below; measured number above the stated range.
By their numbers in this assay, from the lowest: compound 1; then compounds 2 and 3 (each within the scatter of the next).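

Fluoro in place of hydrogen on this aromatic carbon is not a neutral change in this assay: going from 1-methyl-1H-indol-3-yl to 5-fluoro-1-methyl-1H-indol-3-yl gives a clear loss (a 4.0-fold higher number from compound 1 to compound 3 (0.61 log units; beyond the scatter)). Among these compounds, the earlier step lay on the unsaturated amide chain, so this is the first sign that the fused ring system also moves the number, and that a single fluorine atom is enough. Nothing available accounts for this loss.

As far as these compounds go, it remains open whether chloro or methoxy on the same aromatic carbon would raise the number as fluoro does, and whether fluoro elsewhere on that six-membered ring would do the same.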